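Three Limits and a Demethylated Fourth Compound

The source may report more compounds than this note shows. Statements on the series, on what has been measured and on what is new or still open speak of the compounds shown alone.

Compound 1 `Cc1nc(Nc2ccc(Cl)cc2)sc1C(=O)/C=C/c1ccccc1`: in a functional assay on Bel-7402 cells (Homo sapiens) for cytotoxicity, read by MTT assay (a higher number here means a weaker inhibitor, a lower number a stronger inhibitor), compound 1 gives > 25000 nM, which is a limit of the assay and not a number.
Compound 2 `COc1cccc(/C=C/C(=O)c2sc(Nc3ccccc3)nc2C)c1`: in this assay compound 2 gives > 25000 nM, again a limit.
Compound 3 `Cc1ccccc1Nc1nc(C)c(C(=O)/C=C/c2ccccc2)s1`: in this assay compound 3 gives > 25000 nM, also a limit.

Compound 3 therefore stands nowhere distinct from the other two measured compounds: all three sit at the limit of > 25000 nM in this assay, at which 3 of the 3 values shown sit. Within the data shown here, the only single-point step among them, a step that the two limits leave unreadable from compound 1 to compound 3, cannot be sized because the limit of > 25000 nM in this assay, at which 3 of the 3 values shown sit, covers both of its ends, so swapping a 2-methylphenyl for a 4-chlorophenyl on the ring nitrogen taught nothing about direction.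

Compound 4 `Cc1nc(Nc2ccccc2)sc1C(=O)/C=C/c1ccccc1` follows from compound 3 by hydrogen in place of methyl on an aromatic carbon, the methyl leaving an aromatic carbon of a six-membered aromatic ring of carbon only, so that (2-methylphenyl)amino becomes anilino. Among the measured compounds shown here, no measured step shows what removing a methyl there does; the one step that touches this ring is unreadable. Nothing in the data foreshadows a rise into measurable potency, and the expected step is a number no higher from compound 3 to compound 4 (the limit leaves the size open), that is, no readable movement. Compound 4 is accordingly expected to give 25000 nM, estimated to fall between 10000 nM and 60000 nM, most likely reported once more as a limit.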

Compound 4, half-maximal inhibitory concentration: > 25000 nM
Compound 4 gave a limit, no number; the forecaster's own chance of this, stated with the estimate: 85%; the middle value sits exactly at the limit.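

Compound 4 joins compound 1, compound 2 and compound 3 at a limit in this assay, so none of the steps from those three compounds to compound 4 can be read: the limit of > 25000 nM in this assay, at which 4 of the 4 values shown sit.

The compounds shown leave open whether any change on the anilino group or elsewhere on the shared core would give a measurable value.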